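The compounds below may be only part of what the source reports. "The series", "measured", "known", "first", "only" and "open" are said of these compounds alone.

Measured so far:
- compound 1, `COc1ccc(SCc2ccc(/C=C/C(=O)Nc3ccccc3N)cc2)cc1OC`: 14.3%
- compound 2, `Nc1ccccc1NC(=O)c1ccc(CSc2ccc(Br)cc2)cc1`: 10%

In a functional assay on SMMC-7721 cells (Homo sapiens) for inhibition, read by CCK-8 assay, with a stated time of 72 h, tested at 2 uM (a higher number here means more inhibition of growth at the concentration tested, a lower number less inhibition of growth), compound 1 gives 14.3% and compound 2 gives 10%. Compound 2 stands at a number that differs from that of compound 1 by less than the scatter of the measurement, so the two cannot be told apart; both show weak growth inhibition.

Compound 3, `CC(C)(C)c1ccc(SCc2ccc(C(=O)Nc3ccccc3N)cc2)cc1`, has not yet been measured. It differs from compound 2 in one place: tert-butyl in place of bromo on an aromatic carbon. Among the measured compounds shown here, no step between measured compounds with this kind of change is known, so there is no footing for a change beyond the scatter. The expected step of a number 2 percentage points higher from compound 2 to compound 3 (within the scatter) is therefore small, with no clear direction. Compound 3 is estimated at 12%, with a range from 2% to 26%.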

Compound 3, percent growth inhibition at one concentration: 23.6%
For compound 3 the middle estimate is 11.6 percentage points below the measured one; measured number inside the range.
By their numbers in this assay, from the lowest: compounds 2, 1 and 3 (each within the scatter of the next, the first and the last beyond it).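

In this assay, tert-butyl in place of bromo on this aromatic carbon, para to a large group, gives a number 13.6 percentage points higher from compound 2 to compound 3 (beyond the scatter). The position is therefore not indifferent to what sits on it: a modest gain comes with four carbon atoms replacing one bromine atom. No measurement shown gives a reason for this rise.

On these data alone, whether the gain comes from adding the carbon atoms or from losing the bromine stays open, and a methyl group, a chlorine atom or an amine on this carbon would help separate the two. As far as these compounds go, whether the same change acts alike on the core of compound 1 also stays open.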